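Nitro for Fluoro on a Shared Indole-Type Core

The compounds below may be only part of what the source reports. "The series", "measured", "known", "first", "only" and "open" are said of these compounds alone.

Measured so far in an assay on isolated protein for inhibition of Indoleamine 2,3-dioxygenase 1 (Homo sapiens), read by spectrophotometry; on this read-out higher numbers stand for weaker inhibition and lower numbers for stronger inhibition:
compound 1, `O=C(Cc1cccnc1)c1cc2cc(-c3ccccc3)ccc2[nH]1`: 96000 nM
compound 2, `O=C(Cc1cccnc1)c1cc2ccccc2[nH]1`: 65000 nM
compound 3, `O=C(Cc1cccnc1)c1cc2cc(F)ccc2[nH]1`: 36000 nM

Of the compounds shown here, three sharing one core have been measured in this assay. Compound 3 has the lowest number of the three. The step of a 2.7-fold lower number from compound 1 to compound 3 (0.43 log units; beyond the scatter) is a modest one beyond the scatter, whereas a 1.8-fold lower number from compound 2 to compound 3 (0.26 log units; within the scatter) and a 1.5-fold lower number from compound 1 to compound 2 (0.17 log units; within the scatter) both stay within it, so compound 3 cannot be called the strongest inhibitor outright; only its separation from compound 1 is secure.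

Compound 4 `O=C(Cc1cccnc1)c1cc2cc([N+](=O)[O-])ccc2[nH]1` has not yet been measured. It differs from compound 3 in one place: nitro in place of fluoro on an aromatic carbon. Among the measured compounds shown here, no measured step introduces a nitro group, so the two steps into compound 3, one modest and one within the scatter, are the only guide. Both show that changing the group at this place moves the number little. The step into compound 4 is therefore expected to be a 1.2-fold lower number from compound 3 to compound 4 (0.08 log units; within the scatter), with no direction beyond the scatter clearly favoured. Compound 4 is accordingly estimated at 30000 nM, with a range from 10000 nM to 90000 nM.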

Compound 4, half-maximal inhibitory concentration: "not active" (no number reported)
No number was reported for compound 4; the estimate stays without a comparison.
By their numbers in this assay, from the lowest: compounds 3, 2 and 1 (each within the scatter of the next, the first and the last beyond it).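

In this assay, among the compounds shown here, compound 4 gives "not active" (no number reported) and so no step from compound 3 to compound 4 can be read. Nothing shown here bears on this result. The compounds shown leave open how far compound 4 stands from compound 3, and whether any group at this place separates clearly from hydrogen.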